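A few compounds are considered here, and "the series" means these few. Any claim that something is new, unique, unknown or untested is made for them only; others in the source may bear on it.

Values in a functional assay on A549 cells (Homo sapiens) for inhibition, read by MTT assay, with a stated time of 72 h (a higher number here means a weaker inhibitor, a lower number a stronger inhibitor), so far:
- compound 1 `COc1cc2c(Oc3ccc(NC(=O)c4nn(-c5ccccc5C)cc(C)c4=O)cc3F)ccnc2cc1OCCCC(=O)NO` gives 2090 nM 
- compound 2 `COc1cc2c(Oc3ccc(NC(=O)c4nn(-c5ccccc5)cc(C)c4=O)cc3F)ccnc2cc1OCCCC(=O)NO` gives 1900 nM 
- compound 3 `COc1cc2c(Oc3ccc(NC(=O)c4nn(-c5ccccc5F)cc(C)c4=O)cc3F)ccnc2cc1OCCCC(=O)NO` gives 1370 nM 

Compound 3 cannot be separated from the other two in this assay on these numbers. The gaps to it are a 1.5-fold lower number from compound 1 to compound 3 (0.18 log units; within the scatter) and a 1.4-fold lower number from compound 2 to compound 3 (0.14 log units; within the scatter) and neither leaves the scatter.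

Compound 4 `COc1cc2c(Oc3ccc(NC(=O)c4nn(-c5ccccc5F)cc(C)c4=O)cc3)ccnc2cc1OCCCC(=O)NO` comes from compound 3 by a single change (hydrogen in place of fluoro on an aromatic carbon) that puts hydrogen in place of fluoro on an aromatic carbon, ortho to a large group and meta to a large group.

Going by the values given here, no measured step touches that carbon, so the range stays wide. The closest in kind is a 1.4-fold lower number from compound 2 to compound 3 (0.14 log units; within the scatter) for the reverse swap of fluoro and hydrogen on a different aromatic carbon. The remaining step is a 1.1-fold lower number from compound 1 to compound 2 (0.04 log units; within the scatter) and it is just as small. No step beyond the scatter is therefore expected in this assay and no direction can be called.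

The expected step is a 1.1-fold higher number from compound 3 to compound 4 (0.04 log units; within the scatter) as an estimate within the scatter.

For compound 4 the estimated value is 1500 nM with an expected range of 700 nM to 3200 nM for repeat measurements.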

Compound 4, half-maximal inhibitory concentration: 3920 nM
Compound 4: the middle estimate sits 2.6-fold (0.42 log units) below what was measured, outside the stated range (above it).
By their numbers in this assay, from the lowest: compounds 3, 2, 1 and 4 (each within the scatter of the next, the first and the last beyond it).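

In this assay, going by these compounds alone, the aromatic carbon ortho to a large group and meta to a large group is the first place where a single change leaves the scatter: hydrogen in place of fluoro gives a 2.9-fold higher number from compound 3 to compound 4 (0.46 log units; beyond the scatter), a modest step. All earlier steps, made on a different aromatic carbon, stayed within the scatter, so the fluoro on this carbon matters to the number in a way those swaps did not show. Nothing available bears on why the number rises with this change.

On these data alone, whether other groups on this carbon, such as chloro, methoxy or an amine, would match fluoro or hydrogen stays open. Also open, as far as these compounds go, is whether the same step appears when the other aromatic carbon carries methyl or hydrogen, as in compound 1 and compound 2.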